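One fluoro added to compound 2: an estimate

The source may hold more compounds than are shown below. What is called first, only, known or untested is meant among the compounds shown, and "the series" means these compounds.

Measured values in a physicochemical assay for solubility, read by HPLC, in phosphate buffer, with a stated time of 16 h, at pH 6.8; on this read-out higher numbers stand for higher solubility and lower numbers for lower solubility:
- compound 1 `C[C@H](NC(=O)Cn1nnc2ccccc2c1=O)c1ccc(Cl)cc1`: 1900 nM
- compound 2 `Cc1ccc([C@H](C)NC(=O)Cn2nnc3ccccc3c2=O)cc1`: 12000 nM
- compound 3 `Cc1ccc([C@H](C)NC(=O)Cn2nnc3ccccc3c2=O)cn1`: 9800 nM

Compound 2 shares the upper end of these numbers with compound 3, since the gap between them is only a 1.2-fold lower number from compound 2 to compound 3 (0.09 log units; within the scatter). Compound 1 stands apart, and the measured step is a 6.3-fold higher number from compound 1 to compound 2 (0.80 log units; beyond the scatter). The comparison with compound 3 is similar, at a 5.2-fold higher number from compound 1 to compound 3 (0.71 log units; beyond the scatter).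

The next compound to be measured, compound 4 `Cc1ccc([C@H](C)NC(=O)Cn2nnc3ccccc3c2=O)c(F)c1`, differs from compound 2 by fluoro in place of hydrogen on an aromatic carbon. In words, this is fluoro in place of hydrogen on an aromatic carbon, turning 4-methylphenyl into 2-fluoro-4-methylphenyl.

For the measured compounds named here, no measured step adds a fluoro, so the evidence is indirect. Both steps beyond the scatter replace the chloro of compound 1, a group that neither compound 2 nor compound 4 carries. Going by the values given here, the one step that leaves the chloro out of play, a 1.2-fold lower number from compound 2 to compound 3 (0.09 log units; within the scatter), stays within the scatter. No step beyond the scatter is therefore expected in this assay, and the estimate is a 1.3-fold lower number from compound 2 to compound 4 (0.12 log units; within the scatter). Compound 4 is expected near 9000 nM, with an estimated range from 3500 nM to 20000 nM.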

Compound 4, solubility: 4500 nM
Estimate against measurement, compound 4: 2.0-fold (0.30 log units) above; low and high end bracket the measured number.
By their numbers in this assay, from the lowest: compound 1; then compound 4; then compounds 3 and 2 (each within the scatter of the next).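

In this assay, the aromatic carbon ortho to a large group turns out to be sensitive: one fluoro in place of hydrogen, turning 4-methylphenyl into 2-fluoro-4-methylphenyl, gives a 2.7-fold lower number from compound 2 to compound 4 (0.43 log units; beyond the scatter). For the compounds shown here, until now, the only step that left the chloro out of play stayed within the scatter, whereas this change of a single atom moves the number beyond it, and the 2-fluoro-4-methylphenyl group also parts from the 6-methylpyridin-3-yl group, with a 2.2-fold lower number from compound 3 to compound 4 (0.34 log units; beyond the scatter). The loss is only partial, since the new group still stands clear of the 4-chlorophenyl group, with a 2.4-fold higher number from compound 1 to compound 4 (0.37 log units; beyond the scatter).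

No measurement shown here explains why this one fluoro lowers the number. As far as these compounds go, with a single substituent at a single place, it remains open whether a methoxy group or an amine on the same aromatic carbon would lower the number as well, and whether fluoro elsewhere on the ring would give a step of similar size.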